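This account rests on a few compounds, and the source may have more. Where it says the series, first, only, none or still open, it means among the compounds named here.

In a functional assay on DU-145 cells (Homo sapiens) for cytotoxicity, read by MTT assay, with a stated time of 48 h (on this read-out lower numbers stand for stronger inhibition and higher numbers for weaker inhibition), compound 1 `C=C1CCC[C@]2(C)CCC(c3cn(-c4ccc(OC)cc4)nn3)=CC[C@@]12C` gives 58900 nM and compound 2 `C=C1CCC[C@]2(C)CCC(c3cn(-c4ccc(I)cc4)nn3)=CC[C@@]12C` gives 145000 nM, so compound 2 holds the higher of the two numbers and shows the weaker inhibition. Within the data shown here, the only measured step is a 2.5-fold higher number from compound 1 to compound 2 (0.39 log units; beyond the scatter), a modest one, with iodo in place of methoxy on an aromatic carbon. Compound 3 `C=C1CCC[C@]2(C)CCC(c3cn(-c4ccccc4C(C)=O)nn3)=CC[C@@]12C` differs from compound 2 as follows: 2-acetylphenyl in place of 4-iodophenyl on an aromatic nitrogen. In short, 2-acetylphenyl stands in place of 4-iodophenyl on an aromatic nitrogen. Among the measured compounds shown here, the measured step bears on this change only in part, since no measured compound carries an acetyl group. With compound 2 at the top of the pair, and taking the scale from a 2.5-fold higher number from compound 1 to compound 2 (0.39 log units; beyond the scatter), a modest move toward a lower number is expected in this assay. The expected change is a 1.7-fold lower number from compound 2 to compound 3 (0.23 log units; within the scatter). For compound 3 the estimated value is 85000 nM, with an expected range of 35000 nM to 200000 nM.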

Compound 3, half-maximal inhibitory concentration: 48500 nM
Beside the measured number, compound 3's estimate is 1.8-fold (0.24 log units) above it, and the stated range covers the measured number.
By their numbers in this assay, from the lowest: compounds 3 and 1 (each within the scatter of the next); then compound 2.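

In this assay, putting 2-acetylphenyl on the aromatic nitrogen gives a 3.0-fold lower number from compound 2 to compound 3 (0.48 log units; beyond the scatter), so a second group, with its substituent at a different ring place, now stands apart from 4-iodophenyl in the same direction as 4-methoxyphenyl does. The other new step, a 1.2-fold lower number from compound 1 to compound 3 (0.08 log units; within the scatter), leaves compound 3 and compound 1 indistinguishable, which means that among these three compounds only the 4-iodophenyl group of compound 2 separates from the rest, even though 2-acetylphenyl and 4-methoxyphenyl differ in both substituent and ring place. No measurement offered here accounts for these numbers. Still open, from the compounds shown here alone, is whether the acetyl group or its ring place matters more, which 4-acetylphenyl would help to separate. Going by these compounds, it is also open how an amine or a carboxylic acid on the phenyl ring would read in this assay.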